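This account rests on a few compounds, and the source may have more. Where it says the series, first, only, none or still open, it means among the compounds named here.

Of the compounds shown here, two built on one shared core have so far been tested in a functional assay on SUP-B15 cells (Homo sapiens) for antiproliferative activity, with a stated time of 72 h; on this read-out lower numbers stand for an effect already at smaller amounts and higher numbers for an effect only at larger amounts of compound. Compound 1 `COc1ccc(-c2cc(=O)c3c(OC)cc(OC)cc3n2Cc2ccccc2)cc1` reaches only the limit of this assay, > 34400 nM, so no number is known for it. Compound 2 `COc1ccc(-c2c(I)c(=O)c3c(OC)cc(OC)cc3n2S(=O)(=O)c2ccc(OC)cc2)cc1` gives 12300 nM in this assay, a weak effect that needs a large amount of compound. Compound 3 `COc1ccc(-c2cc(=O)c3c(OC)cc(OC)cc3n2S(=O)(=O)c2ccc(Cl)cc2)cc1` has not yet been measured. It differs from compound 1 in one place: (4-chlorophenyl)sulfonyl in place of benzyl on an aromatic nitrogen. Among the measured compounds no pair differs in exactly this way, so the size of the step cannot be read directly; the only guide is that compound 2, the one measured compound with a sulfonyl group on the same aromatic nitrogen, gives 12300 nM. The change from compound 1 to compound 3 is therefore expected to move the value from beyond the limit to a measurable, still weak number, a step of an at least 2.2-fold lower number from compound 1 to compound 3 (0.36 log units; beyond the scatter) in this assay. Compound 3 is expected to give about 15000 nM in this assay, within a range from 4000 nM to 50000 nM.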

Compound 3, half-maximal effective concentration: > 34400 nM
Compound 3 ended at the assay's limit; the forecaster's own chance of this, stated with the estimate: 35%; middle value at least 2.2-fold (0.36 log units) from the limit.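

No step from compound 1 to compound 3 can be read in this assay, since each of the two compounds gives only a limit and not a number: the limit of > 34400 nM in this assay, at which 2 of the 3 values shown sit.

The compounds shown leave open whether (4-chlorophenyl)sulfonyl in place of benzyl on the aromatic nitrogen changes the antiproliferative effect at all, and in which direction.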